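The compounds below may be only part of what the source reports. "The series", "measured", "known", "first", "only" and "open" are said of these compounds alone.

Of the compounds shown here, two have so far been measured in a functional assay on the whole organism with Mus musculus as the target, in the maximal electroshock model, at a dose of 50 mg/kg by the oral route; on this read-out higher numbers stand for more inhibition at the one dose given (going by the name of the read-out) and lower numbers for less inhibition. Compound 1 `CN(C)CCCOc1ccccc1/C=C/c1ccccc1` gives 14.2%. Going by the values given here, compound 2 `C(=C/c1ccccc1OCCCCN1CCCCC1)\c1ccccc1` gives 42.9%, the higher of the two numbers, and the single measured step, a number 28.7 percentage points higher from compound 1 to compound 2 (beyond the scatter), lies beyond the scatter. Compound 3 `C(=C/c1ccccc1OCCCCN1CCNCC1)\c1ccccc1` is the next compound to be tested. It differs from compound 2 in one place: piperazin-1-yl in place of piperidin-1-yl on a saturated chain carbon, four bonds along the chain from an oxygen on an aromatic ring. The change again concerns the amine on the saturated chain carbon, four bonds along the chain from an oxygen on an aromatic ring, as did the step from compound 1 to compound 2; that step, however, exchanged dimethylamino for a ring and says nothing about exchanging piperidin-1-yl for piperazin-1-yl. Among the compounds with values here, no measured step bears directly on this change, and the one step that exists, a number 28.7 percentage points higher from compound 1 to compound 2 (beyond the scatter), was modest. The step is therefore expected to be a number 4.9 percentage points lower from compound 2 to compound 3 (within the scatter), a change within the scatter in this assay. Compound 3 is estimated at 38%, with a range from 15% to 62%.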

Compound 3, a percentage reported as inhibition, in the whole organism at one dose (the size of the read-out at that dose, not a potency): 0%
Compound 3: the middle estimate sits 38 percentage points above what was measured; measured number below the stated range.
By their numbers in this assay, from the lowest: compound 3; then compound 1; then compound 2.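

In this assay, piperazin-1-yl in place of piperidin-1-yl on a saturated chain carbon, four bonds along the chain from an oxygen on an aromatic ring, is a large step, a number 42.9 percentage points lower from compound 2 to compound 3 (beyond the scatter), so at this place the read-out separates two groups that share 6 heavy atoms and one six-membered non-aromatic ring but differ in a second ring nitrogen and in 1 hydrogen-bond donor. The ring in itself therefore does not carry the gain seen in a number 28.7 percentage points higher from compound 1 to compound 2 (beyond the scatter), since (piperazin-1-yl)methyl in place of dimethylamino goes the other way, a number 14.2 percentage points lower from compound 1 to compound 3 (beyond the scatter). Nothing available explains why the second ring nitrogen goes with this loss.

The compounds shown leave open whether the loss follows the ring nitrogen with its hydrogen or any second hetero atom in the ring, a question that a methylpiperazine or a morpholine at the same place would address. They also leave open how far the number for compound 2 depends on the size of the ring, as a pyrrolidine or an azepane there would show.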